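The compounds below may be only part of what the source reports. "The series", "measured", "known", "first", "only" and "open" are said of these compounds alone.

In a functional assay on NALM-6 cells (Homo sapiens) for cytotoxicity, read by luminescence and CellTiter-Glo, with a stated time of 3 days (on this read-out lower numbers stand for stronger inhibition and higher numbers for weaker inhibition), compound 1 (`N#Cc1cccc(NC(=O)c2cc(F)ccc2O)c1`) stands at "not determined" (no result reported) and so gives no number to start from. Within the data shown here, the only number nearby is from compound 2 (`O=C(Nc1ccc(C(F)(F)F)cc1)c1cc(Br)c(F)cc1O`), at 1300 nM on a differently substituted structure. Compound 3 (`O=C(Nc1cccc(OC(F)(F)F)c1)c1cc(F)ccc1O`) has trifluoromethoxy in place of cyano on an aromatic carbon, meta to a large group: trifluoromethoxy in place of cyano on an aromatic carbon is the whole change from compound 1. Among the measured compounds shown here, no measured step shows this change in this assay, so no step of known size or direction is expected beyond the scatter. Anchored on compound 2, the expected value for compound 3 is 2000 nM with 500 nM to 8000 nM as the estimated range.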

Compound 3, half-maximal inhibitory concentration: 1370 nM
Compound 3: the middle estimate sits 1.5-fold (0.16 log units) above what was measured, and the stated range covers the measured number.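

Among these compounds, compound 1 ("not determined" (no result reported)) and compound 3 (1370 nM) yield no new step. From the compounds shown here alone, the effect of trifluoromethoxy in place of cyano on the measured value stays open, and nothing available bears on this result.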